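A methyl group moves on a long-lived compound

A few compounds are considered here, and "the series" means these few. Any claim that something is new, unique, unknown or untested is made for them only; others in the source may bear on it.

Compound 1 `Cc1cc(CCCOc2c(C)cc(-c3ccccc3)cc2C)on1` was measured in an in vitro ADME assay on microsomes from liver for metabolic stability; on this read-out lower numbers stand for a shorter-lived compound and higher numbers for a longer-lived compound. In this assay compound 1 gives > 3.33 h, which is a limit and not a number. Compound 2 `Cc1cccc(-c2cc(C)c(OCCCc3cc(C)no3)c(C)c2)c1` has a methyl in place of hydrogen on an aromatic carbon. Compound 2 gives > 3.33 h, which is also a limit. Compound 2 therefore has no exact half-life to start from, and the evidence so far is the limit of > 3.33 h in this assay, at which 2 of the 2 values shown sit. Going by the values given here, the only measured change is a step that the two limits leave unreadable from compound 1 to compound 2, so it offers no size to carry forward.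

Compound 3 `Cc1ccc(-c2cc(C)c(OCCCc3cc(C)no3)c(C)c2)cc1` has the same atoms as compound 2, joined differently: 4-methylphenyl in place of 3-methylphenyl on an aromatic carbon. Here, 4-methylphenyl stands in place of 3-methylphenyl on an aromatic carbon. With no readable step to guide it, the expectation in this assay is no change beyond the scatter and no particular direction. The expected size is a step that the limit leaves unreadable from compound 2 to compound 3, an estimate resting on compound 2 and its reading of > 3.33 h. A further limit is the most likely report. Compound 3 is estimated at 4 h, with an expected range from 2.2 h to 7.5 h.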

Compound 3, half-life: > 3.33 h
Compound 3: no number, only a limit; the forecaster's own chance of this, stated with the estimate: 75%; the middle value lies beyond the limit too.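

No step can be read among compound 1, compound 2 and compound 3, because each reports only a limit and not a number: the limit of > 3.33 h in this assay, at which 3 of the 3 values shown sit. In this assay the compounds shown leave open how long each one actually lasts, and whether 4-methylphenyl in place of 3-methylphenyl makes any difference to that half-life.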